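The compounds below may be only part of what the source reports. "The series", "measured", "known", "first", "only" and "open" are said of these compounds alone.

Compound 1, `COc1cc(-c2cc(/C=C/C(=O)c3ccc(N)cc3)[nH]n2)cc(OC)c1OC`: 3920 nM
Compound 2, `COc1ccc(-c2cc(/C=C/C(=O)c3ccc(OC)c(OC)c3)[nH]n2)cc1`: 6170 nM

Of the compounds shown here, two have been measured in a functional assay on HOP-62 cells (Homo sapiens) for inhibition, read by sulforhodamine B assay, with a stated time of 48 h; a higher number here means a weaker inhibitor of growth, a lower number a stronger inhibitor of growth. In this assay compound 1 gives 3920 nM, and compound 2 gives 6170 nM. Compound 1 shows the lower of the two numbers, but the gap to compound 2 lies within the usual scatter, so the two cannot be told apart on these data.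

The next compound, compound 3, is `COc1cc(-c2cc(/C=C/C(=O)c3ccc(Cl)c(Cl)c3)[nH]n2)cc(OC)c1OC`. It differs from compound 1 in one place: 3,4-dichlorophenyl in place of 4-aminophenyl on a carbonyl carbon. The shared core of compound 1 is kept, and only the group on the carbonyl carbon changes. Going by the values given here, no step between two measured compounds covers a change of this kind, so there is nothing here to set the size of the step from. The step from compound 1 to compound 3, a 1.3-fold higher number from compound 1 to compound 3 (0.11 log units; within the scatter), is expected to stay within the scatter, in either direction. For compound 3 the expected value in this assay is 5000 nM, within a range of 1500 nM to 16000 nM.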

Compound 3, concentration for total growth inhibition: 7660 nM
Estimate against measurement, compound 3: 1.5-fold (0.19 log units) below, and the stated range covers the measured number.
By their numbers in this assay, from the lowest: compounds 1, 2 and 3 (each within the scatter of the next).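

In this assay, putting 3,4-dichlorophenyl in place of 4-aminophenyl on the carbonyl carbon gives a 2.0-fold higher number from compound 1 to compound 3 (0.29 log units; within the scatter) and so does not separate the two compounds. Going by these compounds alone, this is the first step that can be read at this position: the group that enters has no hydrogen-bond donors or acceptors and carries two chlorine atoms, yet compound 1 and compound 3 cannot be told apart in this measurement. Nothing measured here offers an explanation for this result.

The compounds shown leave open whether a quite different group on this carbonyl carbon, such as a carboxylic acid or a simple methyl, would give a number beyond the scatter. They also leave open where a phenyl ring carrying a single chlorine would fall.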